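Methyl in Place of Pyridin-3-yl on an Amine Nitrogen

The compounds below may be only part of what the source reports. "The series", "measured", "known", "first", "only" and "open" are said of these compounds alone.

Compound 1, `Cc1cccc(NN=C2CCC(C)n3c2ncc(C(=O)O)c3=O)c1C`: in a functional assay on the whole organism with Rattus norvegicus as the target (on this read-out higher numbers stand for an effect only at larger amounts of compound and lower numbers for an effect already at smaller amounts), compound 1 gives > 100 umol/kg, a limit of the assay.
Compound 2, `Cc1cccc(C)c1NN=C1CCC(C)n2c1ncc(C(=O)O)c2=O`: in this assay compound 2 gives 320 umol/kg.
Compound 3, `CC1CCC(=NNc2cccnc2)c2ncc(C(=O)O)c(=O)n21`: in this assay compound 3 gives > 320 umol/kg, again only a limit.

Compound 3 thus stands at the limit of > 320 umol/kg in this assay, at which 1 of the 3 values shown sits, not at a number. Compound 4, `CNN=C1CCC(C)n2c1ncc(C(=O)O)c2=O`, differs from it in one place: methyl in place of pyridin-3-yl on an amine nitrogen. Going by the values given here, no measured step reads out a size that bears on this change: a step that the limit leaves unreadable from compound 1 to compound 2, a step that the two limits leave unreadable from compound 1 to compound 3 and a number no lower from compound 2 to compound 3 (the limit leaves the size open) all stay unreadable because of the limits. So no direction beyond the scatter is expected, and the step that the limit leaves unreadable from compound 3 to compound 4 is estimated as small. Compound 4 is expected near 500 umol/kg, within 150 umol/kg to 2000 umol/kg, most likely reported once more as a limit.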

Compound 4, dose for 50% inhibition: > 100 umol/kg
Compound 4: only a limit was reported; the forecaster's own chance of this, stated with the estimate: 70%; the middle value lies beyond the limit too.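

Going by these compounds alone, in > 100 umol/kg compound 4 reaches only a limit of the assay, so no step from compound 1, compound 2 or compound 3 to compound 4 can be read. The compounds shown leave open whether changing the group on the amine nitrogen alters the result in this assay at all.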